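The compounds below may be only part of what the source reports. "The series", "measured", "known", "first", "only" and "open" are said of these compounds alone.

For the measured compounds named here, compound 2 `Nc1ccccc1NC(=O)c1ccc(CSc2ccc(F)cc2)cc1` stands lowest of the two compounds measured so far: in a functional assay on SMMC-7721 cells (Homo sapiens) for inhibition, read by CCK-8 assay, with a stated time of 72 h, tested at 2 uM (a lower number here means less inhibition of growth, a higher number more inhibition of growth at the concentration tested), compound 2 gives 6.58%, while compound 1 `Cc1cc(C)cc(SCc2ccc(C(=O)Nc3ccccc3N)cc2)c1` gives 29.1%. Going by the values given here, the only measured step between these two, a number 22.5 percentage points lower from compound 1 to compound 2 (beyond the scatter), shows that exchanging the group on the sulfur can move the read-out by a modest amount beyond the scatter.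

Compound 3 `Nc1ccccc1NC(=O)c1ccc(CSCCc2ccccc2)cc1` differs from compound 2 by phenethyl in place of 4-fluorophenyl on a sulfur. Among the compounds with values here, no measured pair shows this particular exchange, so the step from compound 1 to compound 2 bears on it only as a precedent for the size of change that a swap at the same sulfur can produce, not for its direction. With the 3,5-dimethylphenyl giving the higher number and the 4-fluorophenyl the lower, the phenethyl has no measured neighbour to lean on. The expected step of a number 8.4 percentage points higher from compound 2 to compound 3 (within the scatter) is therefore a modest one, most likely upward from the low value of compound 2 but possibly within the scatter. For compound 3 the estimate in this assay is 15%, expected to lie between 0% and 40%.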

Compound 3, percent growth inhibition at one concentration: 28.1%
For compound 3 the middle estimate is 13.1 percentage points below the measured one, and the stated range covers the measured number.
By their numbers in this assay, from the lowest: compound 2; then compounds 3 and 1 (each within the scatter of the next).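

In this assay the exchange of 4-fluorophenyl for phenethyl on the sulfur gives a number 21.5 percentage points higher from compound 2 to compound 3 (beyond the scatter) and so becomes the second swap at this sulfur to move the read-out beyond the scatter, now with a group that carries its ring on a saturated chain. Set against the 3,5-dimethylphenyl, the phenethyl gives a number 1 percentage points lower from compound 1 to compound 3 (within the scatter) and the two groups cannot be told apart here, which means that the low number belongs to compound 2 alone among the three and does not follow from every departure from the 3,5-dimethylphenyl. Nothing at hand explains why the 4-fluorophenyl stands apart from the other two groups.

The compounds shown leave open whether the low number of compound 2 goes with the fluorine or with the plain ring it sits on, as an unsubstituted phenyl on the sulfur is not among them. Also open, as far as these compounds go, is whether a longer chain than phenethyl, or a chain ending in an amine or a carboxylic acid, would keep the read-out of compound 3 or lose it.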